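Replacing a methyl with 2-methoxyethoxy on a quinone carbamate

This account rests on a few compounds, and the source may have more. Where it says the series, first, only, none or still open, it means among the compounds named here.

Of the compounds shown here, three sharing one core have been measured: compound 1 `CC1=C(N2CC2)C(=O)C(CC(C)OC(N)=O)=C(N2CC2)C1=O`, compound 2 `CCOC(COC(N)=O)C1=C(N2CC2)C(=O)C(C)=C(N2CC2)C1=O` and compound 3 `CC1=C(N2CC2)C(=O)C(C(C)COC(N)=O)=C(N2CC2)C1=O`. In a functional assay on L1210 cells (Mus musculus), with a stated time of 1 days (on this read-out higher numbers stand for higher potency (the scale is a negative logarithm) and lower numbers for lower potency), compound 3 gives 5.93, the highest of the three numbers, while compound 1 gives 5.86 and compound 2 gives 5.53. The step of a number 0.07 log units higher from compound 1 to compound 3 (within the scatter), and the step of a number 0.40 log units higher from compound 2 to compound 3 (beyond the scatter). Compound 4 `COCCOC(COC(N)=O)C1=C(N2CC2)C(=O)C(C)=C(N2CC2)C1=O` is not yet measured; it differs from compound 3 by 2-methoxyethoxy in place of methyl on a saturated chain carbon bound to a double-bonded ring carbon and a saturated chain carbon. The step from compound 2 to compound 3 bears on this, since it changed the same place by a similar kind of group. The expected step is therefore a number 0.43 log units lower from compound 3 to compound 4 (beyond the scatter), and compound 4 is expected to give 5.5, within 5.1 to 5.9.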

Compound 4, logarithm of the reciprocal of the active concentration, log(1/C): 5.45
Compound 4: middle estimate off by 0.05 log units, on the high side, within the range that was stated.
By their numbers in this assay, from the lowest: compounds 4 and 2 (each within the scatter of the next); then compounds 1 and 3 (each within the scatter of the next).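

In this assay, the 2-methoxyethoxy group in place of methyl at this saturated chain carbon gives a number 0.48 log units lower from compound 3 to compound 4 (beyond the scatter). Adding a methoxy to the ethoxy chain gives a number 0.08 log units lower from compound 2 to compound 4 (within the scatter), so extending this ether chain leaves the number within the scatter, and both ether compounds sit below compound 3. Nothing measured here gives a reason for this. Still open, going by these compounds, is how an amine, a carboxylic acid or a plain propyl chain would read at this place. A propyl chain would help show whether the ether oxygen or the chain itself goes with the lower numbers.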